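A few compounds are considered here, and "the series" means these few. Any claim that something is new, unique, unknown or untested is made for them only; others in the source may bear on it.

In a functional assay on MIA PaCa-2 cells (Homo sapiens) for cytotoxicity, read by WST assay, with a stated time of 48 h (on this read-out lower numbers stand for stronger inhibition and higher numbers for weaker inhibition), compound 1 `COc1ccc2c(/C=C(\C#N)C(=O)c3c[nH]c4cc(OC)ccc34)c[nH]c2c1` gives > 50000 nM, which is a limit of the assay and not a number. Within the data shown here, compound 2 `N#C/C(=C\c1c[nH]c2cc(F)ccc12)C(=O)c1c[nH]c2ccccc12` gives 31600 nM, the only actual number available here, so it stands alone on this scale with no second figure to compare it against. Compound 3 `COc1ccc2c(C(=O)/C(C#N)=C/c3c[nH]c4cc(F)ccc34)c[nH]c2c1` differs from compound 2 by methoxy in place of hydrogen on an aromatic carbon. Among the measured compounds shown here, no measured step isolates this change. For the measured compounds named here, the only guide is that compound 1 also carries methoxy and sits at the limit of > 50000 nM, so no gain in this assay is expected. The expected change, a 1.1-fold higher number from compound 2 to compound 3 (0.04 log units; within the scatter), is estimated to stay within the usual scatter, if anything towards weaker inhibition. For compound 3 the estimate is 35000 nM, with an expected range from 15000 nM to 50000 nM.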

Compound 3, half-maximal inhibitory concentration: > 50000 nM
Compound 3: only a limit was reported; the forecaster's own chance of this, stated with the estimate: 35%; middle value at least 1.4-fold (0.15 log units) from the limit.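

In this assay, methoxy in place of hydrogen on an aromatic carbon, on the ring that is meta and para to a fused ring, gives an at least 1.5-fold higher number from compound 2 to compound 3 (0.19 log units; that floor lies within the scatter), the first direct measure of this change, and it shows no gain in inhibition. Compound 3 gives > 50000 nM, which is a limit of the assay and not a number, so the size of this step is only a floor and does not establish a real loss. The step between compound 1 and compound 3 cannot be read: the limit of > 50000 nM in this assay, at which 2 of the 3 values shown sit.

The compounds shown leave open how far above that floor the true effect of methoxy lies. They also leave open whether a hydroxyl group, an amine or a chlorine atom at this position would give a lower number than compound 2.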